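Series notes: chain terminus on the triazole nitrogen substituent

The source may report more compounds than this note shows. Statements on the series, on what has been measured and on what is new or still open speak of the compounds shown alone.

Measured compounds:
compound 1 `Cn1c(Cc2nn(C)c(=O)c3ccccc23)nnc1SCC(=O)Nc1ccc(Cl)cc1Cl` — 7700 nM
compound 2 `Cn1nc(Cc2nnc(SCCCCCCCC(=O)Nc3ccc(Cl)cc3Cl)n2CCC=O)c2ccccc2c1=O` — 960 nM
compound 3 `Cn1nc(Cc2nnc(SCC(=O)Nc3ccc(Cl)cc3Cl)n2CCC(=O)O)c2ccccc2c1=O` — > 30000 nM

In an assay on NK92 cells for inhibition of interleukin-2 (Homo sapiens), read by AlphaScreen, with stated times of 30 min and 1 h (a higher number here means a weaker inhibitor, a lower number a stronger inhibitor), compound 2, at 960 nM, holds the lowest of the two numbers; compound 1 gives 7700 nM. The value of compound 3 is a limit of the assay, not a number, (the limit of > 30000 nM in this assay, at which 1 of the 3 values shown sits).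

Compound 4 `Cn1nc(Cc2nnc(SCCCCCCCC(=O)Nc3ccc(Cl)cc3Cl)n2CCCO)c2ccccc2c1=O` is not yet measured. It differs from compound 2 by hydroxymethyl in place of formyl on a saturated chain carbon, two bonds along the chain from an aromatic nitrogen.

For the measured compounds named here, one measured step touches the same chain: an at least 3.8-fold higher number from compound 1 to compound 3 (0.59 log units; beyond the scatter). That step put a carboxylic acid at the end of the chain on the aromatic nitrogen and gave a weaker number; it does not directly compare a formyl with a hydroxymethyl terminus. The exchange of formyl for hydroxymethyl keeps the chain length and the count of heavy atoms, so in this assay the step of a 1.4-fold higher number from compound 2 to compound 4 (0.13 log units; within the scatter) is expected to stay within the scatter, with no clear direction. Compound 4 is therefore estimated at 1300 nM, with a range from 400 nM to 4500 nM.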

Compound 4, half-maximal inhibitory concentration: > 30000 nM
Compound 4: only a limit was reported; the forecaster's own chance of this, stated with the estimate: 5%; middle value at least 23-fold (1.36 log units) away from the limit.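

In this assay, the exchange of formyl for hydroxymethyl on this chain, with its length and heavy-atom count unchanged, is far from neutral: an at least 31-fold higher number from compound 2 to compound 4 (1.49 log units; beyond the scatter). The value of compound 4, > 30000 nM, is a limit of the assay and not a number. The earlier step, an at least 3.8-fold higher number from compound 1 to compound 3 (0.59 log units; beyond the scatter), brought in a carboxylic acid on a shorter sulfur chain, whereas this one changes only the chain terminus with the long sulfur chain of compound 2 held fixed, and the series now has a second compound at the same limit: the limit of > 30000 nM in this assay, at which 2 of the 4 values shown sit.

The compounds shown leave open whether compound 2 depends on the formyl itself or only on the absence of the hydroxyl hydrogen. A methyl ether or an amine at the same chain end would bear on this, as would a longer chain carrying either terminus.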